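The source may report more compounds than this note shows. Statements on the series, on what has been measured and on what is new or still open speak of the compounds shown alone.

Values in a functional assay on MT2 cells (Homo sapiens) for cytotoxicity, read by MTT assay; a lower number here means that less compound is tolerated, a higher number that more compound is tolerated:

- Compound 1 `CC(C)=CCOc1cc(Nc2nccs2)ccc1C`: 17000 nM
- Compound 2 `CC(C)=CCOc1cc(Nc2nccs2)ccc1C#N`: 750 nM
- Compound 3 `CC(C)=CCOc1cc(Nc2nccs2)ccc1C(=O)O`: not yet measured

Of the two measured compounds, compound 2 holds the lower number, 750 nM. Compound 3 carries carboxy in place of cyano on an aromatic carbon, ortho to a (3-methylbut-2-en-1-yl)oxy group and para to a (1,3-thiazol-2-yl)amino group: carboxy in place of cyano on an aromatic carbon. For the measured compounds named here, only one measured step concerns this same carbon, where cyano replaced methyl: a 23-fold lower number from compound 1 to compound 2 (1.36 log units; beyond the scatter). That single large step shows that a change at this carbon can move the number strongly, so a sizeable step is expected again in this assay, most likely towards a higher number. The expected change is a 20-fold higher number from compound 2 to compound 3 (1.30 log units; beyond the scatter). The estimated value for compound 3 is 15000 nM, within an expected range of 3000 nM to 80000 nM.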

Compound 3, half-maximal cytotoxic concentration: 17000 nM
Compound 3: middle estimate off by 1.1-fold (0.05 log units), on the low side, and the stated range covers the measured number.
By their numbers in this assay, from the lowest: compound 2; then compounds 1 and 3 (each within the scatter of the next).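

In this assay, the drop seen at this carbon does not hold for every replacement of methyl: carboxy in place of cyano brings a 23-fold higher number from compound 2 to compound 3 (1.36 log units; beyond the scatter), while carboxy in place of methyl brings no change at the digits printed from compound 1 to compound 3 (within the scatter). Among the three groups shown at this carbon, cyano alone therefore goes with the low number, while methyl and carboxy leave it unchanged at the digits printed. Nothing available here accounts for the way cyano stands apart from the other two groups.

On these data alone, whether the low number is peculiar to cyano or is shared by other groups on this carbon, such as an amine, an amide or a halogen, stays open. The compounds shown vary only this carbon, so the effect of a longer chain in place of the (3-methylbut-2-en-1-yl)oxy group is also unknown.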